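Methyl for methoxy: a paired step across two cores

The source may report more compounds than this note shows. Statements on the series, on what has been measured and on what is new or still open speak of the compounds shown alone.

Compound 1 `COc1ccc(-c2nnc(COc3ccc(C#N)cc3OC)o2)cc1` carries a 4-methoxyphenyl group; in a functional assay on MDA-MB-453 cells (Homo sapiens) for cytotoxicity, read by MTT assay, with a stated time of 48 h (on this read-out higher numbers stand for weaker inhibition and lower numbers for stronger inhibition), compound 1 gives 13000 nM. Compound 2 `COc1cc(C#N)ccc1OCc1nnc(-c2ccc(C)cc2)o1` differs from it by methyl in place of methoxy on an aromatic carbon, and in this assay compound 2 gives 38400 nM, so the change reads a 3.0-fold higher number from compound 1 to compound 2 (0.47 log units; beyond the scatter). Compound 3 `COc1ccc(-c2nnc(COc3ccc(-c4nnco4)cc3)o2)cc1` is built on a different core; the difference between the two cores is not broken down here. In this assay compound 3 gives 36200 nM, a value close to that of compound 2 and apart from that of compound 1.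

Compound 4 `Cc1ccc(-c2nnc(COc3ccc(-c4nnco4)cc3)o2)cc1` has not yet been measured. It differs from compound 3 by methyl in place of methoxy on an aromatic carbon, the same change as between compound 1 and compound 2, on an aromatic carbon of a six-membered aromatic ring of carbon only, para to a large group. Going by the values given here, only one such step is known, so the expectation is loose. Compound 4 is expected to give about 95000 nM, between 40000 nM and 220000 nM, because a 3.0-fold higher number from compound 1 to compound 2 (0.47 log units; beyond the scatter) was seen for the same change. The expected step is a 2.6-fold higher number from compound 3 to compound 4 (0.42 log units; beyond the scatter), and a value near the upper edge of what this assay can report would not surprise.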

Compound 4, half-maximal inhibitory concentration: > 50000 nM
Compound 4: a limit, no number; the forecaster's own chance of this, stated with the estimate: 30%; the middle value lies beyond the limit too.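

Compound 4 gives > 50000 nM in this assay, which is a limit of the assay and not a number: the limit of > 50000 nM in this assay, at which 1 of the 4 values shown sits. On the core of compound 3, methyl in place of methoxy gives an at least 1.3-fold higher number from compound 3 to compound 4 (0.14 log units; that floor lies within the scatter), so the direction matches the earlier step, but the limit alone does not establish a step beyond the scatter on this core. Carrying the change from one core to the other is therefore compatible with the data but not confirmed, and nothing can be said about whether its size is kept: the same change on two cores in this assay, a 3.0-fold higher number (0.47 log units; beyond the scatter) from compound 1 to compound 2 and an at least 1.3-fold higher number (0.14 log units; that floor lies within the scatter) from compound 3 to compound 4; the limit leaves it open whether they differ.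

The compounds shown hold only methoxy and methyl at this place, which leaves open what an amine, a carboxylic acid or a longer chain such as ethoxy would give there on either core. Also open, from the compounds shown here alone, is whether the step from 4-methoxyphenyl to 4-methylphenyl runs the same way on any third core, as the series here offers only two.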